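A Hydrazide in Place of the Bromophenyl Ketone

A few compounds are considered here, and "the series" means these few. Any claim that something is new, unique, unknown or untested is made for them only; others in the source may bear on it.

Of the compounds shown here, three sharing one core have been tested in a functional assay on HCT-116 cells (Homo sapiens) for cytotoxicity, read by MTT assay, with a stated time of 48 h; on this read-out lower numbers stand for stronger inhibition and higher numbers for weaker inhibition. Compound 1 `O=C(CSCc1nc2cc([N+](=O)[O-])ccc2[nH]1)c1ccc(Br)cc1` gives 1780 nM, the lowest of the three numbers. Compound 2 `N#Cc1sc(Nc2ccccc2)nc1NC(=O)CSCc1nc2cc([N+](=O)[O-])ccc2[nH]1` gives 8430 nM and compound 3 `CCOC(=O)c1c(NC(=O)CSCc2nc3cc([N+](=O)[O-])ccc3[nH]2)sc2c1CCCCC2` gives 7510 nM; both gaps from compound 1 lie beyond the usual scatter, so compound 1 is the strongest inhibitor here. Compound 4 `NNC(=O)CSCc1nc2cc([N+](=O)[O-])ccc2[nH]1` differs from compound 1 in one place: aminoamino in place of 4-bromophenyl on a carbonyl carbon. For the measured compounds named here, no measured pair shows this change, so the expectation rests on the structures alone. Because the group that leaves belongs to compound 1 at 1780 nM, inhibition is expected to weaken by a moderate step, a 3.4-fold higher number from compound 1 to compound 4 (0.53 log units; beyond the scatter). Compound 4 is therefore estimated at 6000 nM, within a range from 2000 nM to 20000 nM.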

Compound 4, half-maximal inhibitory concentration: 5330 nM
For compound 4 the middle estimate is 1.1-fold (0.05 log units) above the measured one; measured number inside the range.
By their numbers in this assay, from the lowest: compound 1; then compounds 4, 3 and 2 (each within the scatter of the next).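

For the compounds shown here, compound 1 and compound 4 form the first pair in this assay that differs in one place, and replacing 4-bromophenyl with aminoamino on this carbonyl carbon gives a 3.0-fold higher number from compound 1 to compound 4 (0.48 log units; beyond the scatter). The group on this carbon therefore affects the read-out, yet compound 4 still gives 5330 nM without the ring or the bromine. Nothing available explains the size of this step.

This single swap cannot separate the part played by the bromine from that of the ring. An unsubstituted phenyl on the same carbonyl carbon would begin to separate them, while a simple amine there remains an open comparison with the aminoamino group.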